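The compounds below may be only part of what the source reports. "The series", "measured", "known", "first", "only" and "open" are said of these compounds alone.

Compound 2 `CC(=O)Nc1nc(-c2cccc(NS(=O)(=O)c3cccc(Br)c3)c2)cs1` stands highest of the two numbers measured in a functional assay on A-375 cells (Homo sapiens) for antiproliferative activity, read by trypan blue exclusion, with a stated time of 48 h, tested at 5 uM (a higher number here means a weaker effect of the compound at the concentration tested, a lower number a stronger effect), where compound 2 gives 67.4%. Its nearest neighbour, compound 1 `CC(=O)Nc1nc(-c2cccc(NS(=O)(=O)c3ccc(Br)cc3)c2)cs1`, gives 19.7% in this assay. Within the data shown here, the only measured step, a number 47.7 percentage points higher from compound 1 to compound 2 (beyond the scatter), is the exchange of 3-bromophenyl in place of 4-bromophenyl on a sulfonyl sulfur, a large move beyond the scatter. Compound 3 `CCCCCCC#Cc1cccc(S(=O)(=O)Nc2cccc(-c3csc(NC(C)=O)n3)c2)c1` differs from compound 2 in that (oct-1-yn-1-yl in place of bromo on an aromatic carbon), meaning oct-1-yn-1-yl in place of bromo on an aromatic carbon. Among the measured compounds shown here, no measured step exchanges the bromo itself for a chain, so the one known step bears on it only by showing that this assay responds strongly to what sits on that ring. The step from compound 2 to compound 3 is therefore expected to be a number 22.4 percentage points lower from compound 2 to compound 3 (beyond the scatter), with no firm direction. Compound 3 is estimated at 45% in this assay, within a wide range from 10% to 85%.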

Compound 3, a percentage reported as activity, at one concentration (the size of the read-out at that concentration, not a potency): 1.2%
Estimate against measurement, compound 3: 43.8 percentage points above, outside the stated range (below it).
By their numbers in this assay, from the lowest: compound 3; then compound 1; then compound 2.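

Exchanging bromo for oct-1-yn-1-yl on this aromatic carbon gives a number 66.2 percentage points lower from compound 2 to compound 3 (beyond the scatter) in this assay, with compound 3 at 1.2%. The earlier step showed only that moving the bromo around the ring changes the read-out, whereas this one shows that the group at this place matters as well, and that a chain of this length goes with a much stronger effect at the concentration tested than bromo does. Nothing on hand accounts for the size of this step.

Open, on these data alone, is whether the triple bond or the length of the chain carries the step, which an octyl chain or a shorter hex-1-yn-1-yl on the same carbon would separate. Also open, as far as these compounds go, is how a chain ending in an amine or a carboxylic acid would read in this assay at this place.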